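Compound 3: methyl in place of bromo

A few compounds are considered here, and "the series" means these few. Any claim that something is new, unique, unknown or untested is made for them only; others in the source may bear on it.

In a functional assay on SK-OV-3 cells (Homo sapiens) for cytotoxicity (on this read-out higher numbers stand for weaker inhibition of growth and lower numbers for stronger inhibition of growth), compound 3 (`CSc1ccc(C2=C(c3ccc(Br)cc3)C(=O)N3CCCC3C2)cc1`) gives 9000 nM and holds the highest of the three numbers measured in this series. Compound 2 (`COc1ccc(C2=C(c3ccc(SC)cc3)CC3CCCN3C2=O)cc1`) gives 3000 nM and compound 1 (`CSc1ccc(C2=C(c3ccc(C)c(C)c3)C(=O)N3CCCC3C2)cc1`) gives 300 nM on the same read-out.

The change to compound 4 (`CSc1ccc(C2=C(c3ccc(C)cc3)C(=O)N3CCCC3C2)cc1`) is methyl in place of bromo on an aromatic carbon and reads as methyl in place of bromo on an aromatic carbon, that is, 4-bromophenyl to 4-methylphenyl.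

Among the compounds with values here, no measured compound carries 4-methylphenyl, so the evidence is indirect. The closest step is the large one, a 30-fold higher number from compound 1 to compound 3 (1.48 log units; beyond the scatter) with 4-bromophenyl in place of 3,4-dimethylphenyl. Two modest steps also bear on it: a 3.0-fold higher number from compound 2 to compound 3 (0.48 log units; beyond the scatter) with bromo in place of methoxy, and a 10-fold higher number from compound 1 to compound 2 (1.00 log units; beyond the scatter) with 4-methoxyphenyl in place of 3,4-dimethylphenyl. Compound 1 and compound 2 both give lower numbers than compound 3, so a lower number is expected once bromo leaves. The expected step is a 6.0-fold lower number from compound 3 to compound 4 (0.78 log units; beyond the scatter) in this assay and would be modest, recovering only part of the large step seen with compound 1 at 300 nM on the same read-out. Compound 4 is estimated at 1500 nM (expected range 400 nM to 6000 nM).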

Compound 4, concentration for 50% growth inhibition: 9000 nM
The estimate for compound 4 lay 6.0-fold (0.78 log units) below the measured number; the whole stated range lies below it.
By their numbers in this assay, from the lowest: compound 1; then compound 2; then compounds 3 and 4 (each within the scatter of the next).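

In this assay, bromo and methyl on an aromatic carbon para to a large group cannot be told apart, with no change at the digits printed from compound 3 to compound 4 (within the scatter), so among these two groups the swap gives no handle on growth inhibition. Methoxy stays distinct from methyl as well as from bromo, with a 3.0-fold higher number from compound 2 to compound 4 (0.48 log units; beyond the scatter), which puts methoxy alone apart from the other two groups at this place among the compounds that differ only there. The larger new finding lies in the single methyl that separates 4-methylphenyl from 3,4-dimethylphenyl: hydrogen in place of that methyl gives a 30-fold higher number from compound 1 to compound 4 (1.48 log units; beyond the scatter), so the low number of compound 1 goes with the full 3,4-dimethylphenyl group and not with a 4-methyl group on its own.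

Nothing measured in this series gives a reason for any of these steps. Still open, on these data alone, is whether an ethyl group, an amine or a carboxylic acid on the same aromatic carbon would stay with bromo and methyl, and whether a group such as fluoro could stand in for the extra methyl of compound 1.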